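The source may hold more compounds than are shown below. What is called first, only, known or untested is meant among the compounds shown, and "the series" means these compounds.

Compound 1 `FC(F)(F)c1c(CN2CCC(c3ccccc3)CC2)ccn2c(CC3CC3)nnc12`: 261%
Compound 2 `FC(F)(F)c1c(CN2CCCC(c3ccccc3)C2)ccn2c(CC3CC3)nnc12`: 240%
Compound 3 `Fc1ccccc1C1CCN(Cc2ccn3c(CC4CC4)nnc3c2C(F)(F)F)CC1`: 353%

In an assay on CHO cells for positive allosteric modulation of metabotropic glutamate receptor 2 (Homo sapiens), read by scintillation counting, with a stated time of 30 min (on this read-out lower numbers stand for smaller maximal responses and higher numbers for larger maximal responses), compound 3 stands highest of the three, with compound 1 nearest and compound 2 furthest, both gaps beyond the scatter. Compound 4 `FC(F)(F)c1c(CN2CCC(c3ccccc3Cl)CC2)ccn2c(CC3CC3)nnc12` differs from compound 3 in one place: chloro in place of fluoro on an aromatic carbon. Going by the values given here, only one measured step touches this phenyl ring, a number 92 percentage points higher from compound 1 to compound 3 (beyond the scatter), a large rise. Among the compounds with values here, that step swaps hydrogen for fluoro, whereas the step to compound 4 swaps fluoro for chloro, so no measured pair shows this exchange directly. The account therefore expects a number 23 percentage points lower from compound 3 to compound 4 (beyond the scatter), a change within or just beyond the scatter rather than another large jump. Compound 4 is estimated at 330%, in a range from 250% to 410%.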

Compound 4, largest response reached (Emax), in percent of the reference or control that the assay uses: 328%
For compound 4 the middle estimate is 2 percentage points above the measured one; the measured number falls inside the stated range.
By their numbers in this assay, from the lowest: compound 2; then compound 1; then compound 4; then compound 3.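

In this assay the two halogens at this place are not interchangeable: the exchange gives a number 25 percentage points lower from compound 3 to compound 4 (beyond the scatter) and so gives up part of the response. Yet the rise over hydrogen does not belong to fluoro alone, as chloro gives a number 67 percentage points higher from compound 1 to compound 4 (beyond the scatter) and thus a large gain of its own. The data offer no measured explanation for either step.

From the compounds shown here alone, whether a methyl or a methoxy group at this place would also raise the response stays open. So does the outcome of a fluoro or chloro on another carbon of the phenyl ring.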